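A few compounds are considered here, and "the series" means these few. Any claim that something is new, unique, unknown or untested is made for them only; others in the source may bear on it.

Measured so far in a functional assay on NCI-H661 cells (Homo sapiens) for antiproliferative activity, read by MTT assay, with a stated time of 72 h; on this read-out higher numbers stand for weaker inhibition and lower numbers for stronger inhibition:
- compound 1 `O=C(CCCCCCc1nc(-c2cccc([N+](=O)[O-])c2)no1)NO` gives 16100 nM
- compound 2 `Nc1ccccc1NC(=O)CCCCCCc1nc(-c2ccccc2Cl)no1` gives 8310 nM
- compound 3 `Nc1ccccc1NC(=O)CCCCCCc1nc(-c2cccc([N+](=O)[O-])c2)no1` gives 7290 nM

On these numbers, compound 3 sits level with compound 2 and under compound 1. Within the data shown here, the next compound to consider is the unmeasured compound 4 `O=C(CCCCCCc1nc(-c2cccc([N+](=O)[O-])c2)no1)C(F)(F)F`, which keeps the rest of compound 3 but carries trifluoromethyl in place of (2-aminophenyl)amino on a carbonyl carbon as its single change.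

Two measured steps can be weighed. Putting 3-nitrophenyl in place of 2-chlorophenyl on an aromatic carbon gave a 1.1-fold lower number from compound 2 to compound 3 (0.06 log units; within the scatter) and concerns a different group, so it offers little guidance here. The closer guide changed the group on this same carbonyl carbon: 2-aminophenyl in place of hydroxy on an amide-type nitrogen gave a 2.2-fold lower number from compound 1 to compound 3 (0.34 log units; beyond the scatter) as a modest step. Compound 4 also lacks the 2-aminophenyl group, so a modest move toward a higher number in this assay seems the likeliest outcome. Among the measured compounds shown here, no measured compound carries trifluoromethyl, which leaves the size of that move uncertain. The estimated change is a 1.9-fold higher number from compound 3 to compound 4 (0.28 log units; within the scatter) and remains only an expectation. Compound 4 is expected at 14000 nM within an estimated range of 5500 nM to 35000 nM on this read-out.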

Compound 4, half-maximal inhibitory concentration: 6430 nM
Compound 4: the middle estimate sits 2.2-fold (0.34 log units) above what was measured; the range from low to high includes it.
By their numbers in this assay, from the lowest: compounds 4, 3, 2 and 1 (each within the scatter of the next, the first and the last beyond it).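

In this assay, among these compounds, trifluoromethyl in place of (2-aminophenyl)amino on the carbonyl carbon gives a 1.1-fold lower number from compound 3 to compound 4 (0.05 log units; within the scatter), so a group with a six-membered aromatic ring and hydrogen-bond donors and a smaller group with neither read alike at this position, something the earlier compounds could not show. Trifluoromethyl in place of hydroxyamino on the same carbon gives a 2.5-fold lower number from compound 1 to compound 4 (0.40 log units; beyond the scatter), a modest step, so two very different groups now sit at lower numbers than hydroxyamino, and the 2-aminophenyl ring is not needed to reach that level. Nothing available on these compounds explains why these groups read as they do.

Among the compounds shown here, only three groups have been compared on this carbonyl carbon, so a methyl group, giving a simple ketone, or a hydroxy group, giving a carboxylic acid, would help show whether the trifluoromethyl group itself matters or almost any small group would serve. From the compounds shown here alone, it also remains open whether trifluoromethyl would read the same alongside 2-chlorophenyl in place of 3-nitrophenyl on the other end of the molecule.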